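The source may report more compounds than this note shows. Statements on the series, on what has been measured and on what is new or still open speak of the compounds shown alone.

Measured in a functional assay on MDA-MB-231 cells (Homo sapiens) for cytotoxicity, read by MTT assay, with a stated time of 24 h; on this read-out higher numbers stand for weaker inhibition and lower numbers for stronger inhibition:
Compound 1 `Fc1ccc(-c2nc3cccnc3n2C2CCCC2)cc1`: 500 nM
Compound 2 `c1ccc(Oc2ccc(-c3nc4cccnc4n3C3CCCC3)cc2)cc1`: > 10000 nM (a limit of the assay)
Compound 3 `c1cncc(-c2ccc(-c3nc4cccnc4n3C3CCCC3)cc2)c1`: > 10000 nM (a limit of the assay)

Compound 3 gives only a limit in this assay, not a number, and so it stands at the limit of > 10000 nM in this assay, at which 2 of the 3 values shown sit. Going by these compounds, its true value is unknown, which makes any step starting from it hard to size.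

Compound 4 `c1cnc2c(c1)nc(-c1ccc(-c3nnco3)cc1)n2C1CCCC1` keeps the shared core and changes one group: 1,3,4-oxadiazol-2-yl in place of pyridin-3-yl, on an aromatic carbon, para to a large group (1,3,4-oxadiazol-2-yl in place of pyridin-3-yl on an aromatic carbon).

Among the measured compounds shown here, three measured steps bear on this change. Two are large and beyond the scatter: an at least 20-fold higher number from compound 1 to compound 2 (1.30 log units; beyond the scatter) and an at least 20-fold higher number from compound 1 to compound 3 (1.30 log units; beyond the scatter). In both, an aromatic ring group replaces the fluoro of compound 1, and compound 4 also carries an aromatic ring group at that place. The third is the closest match, a swap of one such group for another, but it gives no size: a step that the two limits leave unreadable from compound 2 to compound 3.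

No clear step is therefore expected, and compound 4 should stay close to the limit, or may even be reported only as a limit. The expected change is an at least 1.2-fold lower number from compound 3 to compound 4 (0.09 log units; that floor lies within the scatter). For compound 4 the estimated value is 8000 nM, with an expected range from 1500 nM to 20000 nM.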

Compound 4, half-maximal inhibitory concentration: 87 nM
The estimate for compound 4 lay 92-fold (1.96 log units) above the measured number, and the stated range ends above it.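

Until now, the only ring groups shown on this aromatic carbon, para to a large group, were the phenoxy of compound 2 and the pyridin-3-yl of compound 3, and both came with a large loss; in this assay, the 1,3,4-oxadiazol-2-yl of compound 4 reverses that picture, with a 5.7-fold lower number from compound 1 to compound 4 (0.76 log units; beyond the scatter). So a ring at this place does not by itself weaken the read-out, and the identity of the ring matters, as an at least 110-fold lower number from compound 3 to compound 4 (2.06 log units; beyond the scatter) and an at least 110-fold lower number from compound 2 to compound 4 (2.06 log units; beyond the scatter) show. Both of these steps are floors and their true sizes are unknown, and the step between compound 2 and compound 3 cannot be read, since those two compounds are known only as limits: the limit of > 10000 nM in this assay, at which 2 of the 4 values shown sit.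

Pyridin-3-yl and 1,3,4-oxadiazol-2-yl differ at once in ring size and in the number of hetero atoms, so the compounds shown cannot say which of these differences goes with the lower number. A furan-2-yl, with a five-membered ring and a single hetero atom, or an open-chain amide at the same place would help to separate them.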